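A few compounds are considered here, and "the series" means these few. Any claim that something is new, unique, unknown or untested is made for them only; others in the source may bear on it.

Compound 1 `CC(=O)Oc1ccccc1C(=O)O[C@H]1CO[C@H]2[C@@H]1OC[C@H]2OC(=O)c1ccnn1C` sets the reference point. In an ADME assay on a cell-free system (plasma, Homo sapiens) for metabolic stability, with Plasma (Rattus norvegicus) as the target, read by HPLC, at pH 7.4 (on this read-out higher numbers stand for a longer-lived compound and lower numbers for a shorter-lived compound), compound 1 gives 0.0963 h, the highest of the three measured numbers. Compound 2 `CC(=O)Oc1ccccc1C(=O)O[C@H]1CO[C@H]2[C@@H]1OC[C@H]2OC(C)=O` gives 0.0608 h and compound 3 `CC(=O)Oc1ccccc1C(=O)O[C@H]1CO[C@H]2[C@@H]1OC[C@H]2OC(=O)c1ccccc1C` gives 0.035 h. The step of a 1.6-fold lower number from compound 1 to compound 2 (0.20 log units; within the scatter) stays inside the scatter, whereas a 2.8-fold lower number from compound 1 to compound 3 (0.44 log units; beyond the scatter). Compound 4 `COc1cccc(C(=O)O[C@@H]2CO[C@H]3[C@@H]2OC[C@@H]3OC(=O)c2ccccc2OC(C)=O)c1` differs from compound 1 in one place: 3-methoxyphenyl in place of 1-methyl-1H-pyrazol-5-yl on a carbonyl carbon. The step to compound 3 is the closest guide, as that change also put a six-membered aromatic ring of carbon only on the carbonyl carbon and gave a modest fall; compound 2 adds little. A modest drop is therefore expected, a 2.1-fold lower number from compound 1 to compound 4 (0.33 log units; beyond the scatter). Compound 4 is estimated at 0.045 h, within a range of 0.02 h to 0.1 h.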

Compound 4, half-life: 0.0525 h
Compound 4: the middle estimate sits 1.2-fold (0.07 log units) below what was measured, and the stated range covers the measured number.
By their numbers in this assay, from the lowest: compounds 3, 4, 2 and 1 (each within the scatter of the next, the first and the last beyond it).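

In this assay, 3-methoxyphenyl in place of 1-methyl-1H-pyrazol-5-yl on this carbonyl carbon gives a 1.8-fold lower number from compound 1 to compound 4 (0.26 log units; within the scatter), so a six-membered aromatic ring of carbon only need not produce a step beyond the scatter, as 2-methylphenyl did. The other two comparisons also stay within the scatter: a 1.5-fold higher number from compound 3 to compound 4 (0.18 log units; within the scatter), and a 1.2-fold lower number from compound 2 to compound 4 (0.06 log units; within the scatter). Nothing available explains these results.

Still open, on these data alone, is what a group carrying an amine or a carboxylic acid would give on this carbonyl carbon. A longer chain in place of methyl is equally untested by these compounds.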